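The compounds below may be only part of what the source reports. "The series", "measured", "known", "first", "only" and "open" are said of these compounds alone.

Measured compounds:
compound 1, `CCc1nc2sccn2c1/C=N/OCc1ccc(Cl)c(Cl)c1`, giving 2600 nM in an assay on HepG2 cells for agonist activity at nuclear receptor subfamily 1 group I member 3 (Homo sapiens), read by a luciferase reporter, with a stated time of 23 h; on this read-out lower numbers stand for an effect already at smaller amounts and higher numbers for an effect only at larger amounts of compound
compound 2, `Fc1c(F)c(F)c(CO/N=C/c2c(-c3ccc4ccccc4c3)nc3occn23)c(F)c1F`, giving 1700 nM in this assay

Compound 1 holds the highest of the two numbers in this assay, but compound 2 sits so close that the gap between the two falls within the scatter of repeated measurements, so no order between them can be read from these figures. Compound 3, `FC(F)(F)c1ccc(-c2nc3sccn3c2/C=N/OCc2ccc(Cl)c(Cl)c2)cc1`, has not yet been measured in this assay. It differs from compound 1 in one place: 4-(trifluoromethyl)phenyl in place of ethyl on an aromatic carbon. Within the data shown here, no pair of measured compounds that differ in a single place is available here, so the size of this step cannot be read from a precedent. The account nonetheless expects compound 3 to reach its effect at smaller amounts than compound 1, a step of a 5.2-fold lower number from compound 1 to compound 3 (0.72 log units; beyond the scatter) that should lie beyond the scatter. On that basis compound 3 is estimated at 500 nM in this assay, with a likely range from 100 nM to 2000 nM.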

Compound 3, half-maximal effective concentration: 880 nM
Estimate against measurement, compound 3: 1.8-fold (0.25 log units) below; the measured number falls inside the stated range.
By their numbers in this assay, from the lowest: compounds 3, 2 and 1 (each within the scatter of the next, the first and the last beyond it).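

In this assay the aromatic carbon that bears ethyl in compound 1 now has its first measured step: 4-(trifluoromethyl)phenyl in its place, with 10 heavy atoms where ethyl has 2, gives a 3.0-fold lower number from compound 1 to compound 3 (0.47 log units; beyond the scatter) and so a modest change beyond the scatter. Among these compounds, the position therefore accepts a much larger group carrying a six-membered aromatic ring without any loss, which the earlier compounds, differing from each other in more than one place, could not show. Nothing shown here explains this step.

The compounds shown leave open whether the step belongs to the aromatic ring itself or to its trifluoromethyl group, a question that plain phenyl, a longer chain such as butyl, or a phenyl bearing an amine at this carbon would address. Compound 2 differs from compound 3 in more than one place and cannot settle it.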